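This account rests on a few compounds, and the source may have more. Where it says the series, first, only, none or still open, it means among the compounds named here.

The series rests on a shared core, seen in compound 1 `Nc1scc(CN2CCN(c3cccc(C(F)(F)F)c3)CC2)c1C(=O)c1ccc(Cl)cc1` and compound 2 `Nc1scc(CN2CCN(c3cccnc3)CC2)c1C(=O)c1ccc(Cl)cc1`, which differ only in the group on an amine nitrogen in a ring. In a functional assay on CHO cells with adenosine receptor A1 (Homo sapiens) as the target, read by cAMP accumulation and immunoassay, with a stated time of 6 min, tested at 10 uM (on this read-out higher numbers stand for a weaker effect at the one concentration tested and lower numbers for a stronger effect), compound 1 gives -80%, while compound 2 gives -23%. Among the measured compounds shown here, the single measured step, a number 57 percentage points higher from compound 1 to compound 2 (beyond the scatter), is the only comparison available. Of the two numbers, compound 2 stands highest, which on this read-out means the weaker effect at the one concentration tested.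

Compound 3 `Nc1scc(CN2CCN(c3ccccc3F)CC2)c1C(=O)c1ccc(Cl)cc1` is not yet measured. It differs from compound 2 by 2-fluorophenyl in place of pyridin-3-yl on an amine nitrogen in a ring. For the measured compounds named here, only the step from compound 1 to compound 2 bears on this change: there a six-membered aromatic ring of carbon only gave way to pyridin-3-yl and the number rose by a large amount. Compound 3 brings back a ring of carbon only, yet 2-fluorophenyl is not the same group as 3-(trifluoromethyl)phenyl, so only a partial return is expected, and the expected step is a number 32 percentage points lower from compound 2 to compound 3 (beyond the scatter). Compound 3 is therefore estimated at -55%, within a range from -85% to -20%.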

Compound 3, a percentage reported as activity, at one concentration (the size of the read-out at that concentration, not a potency): -15%
The estimate for compound 3 lay 40 percentage points below the measured number, outside the stated range (above it).
By their numbers in this assay, from the lowest: compound 1; then compounds 2 and 3 (each within the scatter of the next).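

Setting 2-fluorophenyl in place of pyridin-3-yl on the amine nitrogen of the ring gives a number 8 percentage points higher from compound 2 to compound 3 (within the scatter), so at this position a six-membered aromatic ring of carbon only does not in itself bring back the strong effect of compound 1. The step of a number 65 percentage points higher from compound 1 to compound 3 (beyond the scatter) is large and stands alongside a number 57 percentage points higher from compound 1 to compound 2 (beyond the scatter), which leaves 3-(trifluoromethyl)phenyl apart from both other groups among these three compounds, while pyridin-3-yl and 2-fluorophenyl cannot be told apart on this read-out. No measurement is at hand that would explain this difference between the groups.

The compounds shown leave open whether the strong effect of compound 1 goes with the trifluoromethyl group itself or with where it sits on the ring, since fluorine and trifluoromethyl are not compared at the same place. Nor do they show how an unsubstituted phenyl, or a phenyl ring bearing chlorine, a methoxy group or a nitrile, would stand on this same amine nitrogen against these three.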